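Methoxy on the benzylic arm: compound 3 to compound 4

A few compounds are considered here, and "the series" means these few. Any claim that something is new, unique, unknown or untested is made for them only; others in the source may bear on it.

Among the measured compounds shown here, compound 3 `C=C(Br)C(=O)Nc1cccc(-c2cn3nc(CCc4ccccc4)sc3n2)c1` stands second highest of the three numbers so far in a functional assay on FM3A cells (Mus musculus) for inhibition, read by cell counting, with a stated time of 2 days (a lower number here means a stronger inhibitor, a higher number a weaker inhibitor), giving 2600 nM. For the measured compounds named here, its nearest neighbour is compound 2 `C=C(Br)C(=O)Nc1cccc(-c2cn3nc(-c4ccc(OC)c(OC)c4)sc3n2)c1`, which gives 110 nM; the furthest is compound 1 `COc1ccc(Cc2nn3cc(-c4cccc(N)c4)nc3s2)cc1`, which gives 100000 nM, though compound 1 carries a free amine where the other compounds carry the bromoacrylamide, so no single step links it to compound 3. Going by the values given here, the one measured step that bears on the side arm is a 24-fold higher number from compound 2 to compound 3 (1.37 log units; beyond the scatter), a move from an aryl group bound directly to the core to a two-carbon chain ending in phenyl.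

Compound 4 `C=C(Br)C(=O)Nc1cccc(-c2cn3nc(Cc4ccc(OC)cc4)sc3n2)c1` makes a smaller change to compound 3: 4-methoxyphenyl in place of benzyl on a saturated chain carbon bound to an aromatic carbon. The ring is thus drawn one carbon closer to the core and gains a methoxy group, partway back toward the arrangement of compound 2. Given the size of the step from compound 2 to compound 3, a move of the ring back toward the core is expected to lower the number for compound 4 by a modest amount, not the full width of that step, as a 2.6-fold lower number from compound 3 to compound 4 (0.41 log units; beyond the scatter). The estimate for compound 4 in this assay is therefore 1000 nM, within a range from 300 nM to 4000 nM.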

Compound 4, half-maximal inhibitory concentration: 850 nM
Estimate against measurement, compound 4: 1.2-fold (0.07 log units) above; the measured number falls inside the stated range.
By their numbers in this assay, from the lowest: compound 2; then compound 4; then compound 3; then compound 1.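

In this assay the arm can be tuned without returning to a directly bound aryl group: a 3.1-fold lower number from compound 3 to compound 4 (0.49 log units; beyond the scatter) for phenethyl to 4-methoxybenzyl, while a 7.7-fold higher number from compound 2 to compound 4 (0.89 log units; beyond the scatter) shows that 4-methoxybenzyl still falls short of 3,4-dimethoxyphenyl on an aromatic carbon. Among the compounds shown here, with 4-methoxybenzyl held fixed, a 120-fold lower number from compound 1 to compound 4 (2.07 log units; beyond the scatter) gives the first single-place reading of (1-bromoethenyl)carbonyl in place of hydrogen on the nitrogen, and this step far outweighs either change to the arm in these compounds. Nothing measured here accounts for the size of any of these steps.

The step from phenethyl to 4-methoxybenzyl shortens the chain and adds the methoxy at once, so the two changes remain inseparable; a plain benzyl arm on the core and a 2-(4-methoxyphenyl)ethyl arm would divide the effect between them. As far as these compounds go, the part played by the bromine also remains open, and an unsubstituted acryloyl or a 2-chloroacryloyl group on the nitrogen, with the 4-methoxybenzyl arm kept, would address it.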